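Ring substituent series: from compound 3 to compound 4

The source may hold more compounds than are shown below. What is called first, only, known or untested is meant among the compounds shown, and "the series" means these compounds.

- compound 1 `O=C(/C=C/c1ccc(Cl)cc1)Nc1nc2ccccc2s1`: 367 umol/kg
- compound 2 `O=C(/C=C/c1ccc(Cl)cc1)Nc1nc2ccc(Cl)cc2s1`: 204 umol/kg
- compound 3 `Cc1ccc2nc(NC(=O)/C=C/c3ccc(Cl)cc3)sc2c1`: 152 umol/kg

All three values come from a functional assay on the whole organism (Hindlimb, strain albino) with Mus musculus as the target, in the maximal electroshock model, with a stated time of 0.5 h; on this read-out lower numbers stand for an effect already at smaller amounts and higher numbers for an effect only at larger amounts of compound. Compound 3 stands level with compound 2, as a 1.3-fold lower number from compound 2 to compound 3 (0.13 log units; within the scatter) shows, and clear of compound 1, as a 2.4-fold lower number from compound 1 to compound 3 (0.38 log units; beyond the scatter) shows.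

Compound 4 `O=C(/C=C/c1ccc(Cl)cc1)Nc1nc2ccc([N+](=O)[O-])cc2s1` is not yet measured. Its difference from compound 3 is nitro in place of methyl on an aromatic carbon, in words nitro in place of methyl on an aromatic carbon.

Going by the values given here, three measured steps bear on this change. Two replace hydrogen on an aromatic carbon: methyl gives a 2.4-fold lower number from compound 1 to compound 3 (0.38 log units; beyond the scatter), and chloro gives a 1.8-fold lower number from compound 1 to compound 2 (0.26 log units; within the scatter). The third, a 1.3-fold lower number from compound 2 to compound 3 (0.13 log units; within the scatter), exchanges one group for the other. Among the compounds with values here, all are small, and no nitro compound has been measured, so the evidence is indirect. No step beyond the scatter is therefore expected in this assay, with a slight drift towards the value of compound 2 at most.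

The expected step is a 1.3-fold higher number from compound 3 to compound 4 (0.10 log units; within the scatter). For compound 4 the estimated value is 190 umol/kg, with an expected range of 85 umol/kg to 420 umol/kg.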

Compound 4, dose for half-maximal effect: 259 umol/kg
For compound 4 the middle estimate is 1.4-fold (0.13 log units) below the measured one, within the range that was stated.
By their numbers in this assay, from the lowest: compounds 3, 2, 4 and 1 (each within the scatter of the next, the first and the last beyond it).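

In this assay nitro stands level with both earlier substituents on this aromatic carbon, against methyl (a 1.7-fold higher number from compound 3 to compound 4 (0.23 log units; within the scatter)) and against chloro (a 1.3-fold higher number from compound 2 to compound 4 (0.10 log units; within the scatter)). Nitro also stays within the scatter of the unsubstituted compound (a 1.4-fold lower number from compound 1 to compound 4 (0.15 log units; within the scatter)), so, unlike methyl, it does not separate from hydrogen here, and this position accepts a group of three heavy atoms with two hydrogen-bond acceptors without a step beyond the scatter against any compound shown. Nothing on hand accounts for this reading.

As far as these compounds go, whether an amine, a carboxylic acid or a longer chain at this position would shift the number beyond the scatter remains open. Also open, from the compounds shown here alone, is whether methyl, chloro and nitro would keep this level at another place on the shared core.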